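A few compounds are considered here, and "the series" means these few. Any claim that something is new, unique, unknown or untested is made for them only; others in the source may bear on it.

Compound 1 `O=C(Nc1ccc(S(=O)(=O)N2CCC(Cl)CC2)cc1)c1ccc([N+](=O)[O-])o1`: in an ADME assay on IMR-90 cells (Homo sapiens) for cytotoxicity, read by CellTiter-Blue, with a stated time of 46 h (a lower number here means that less compound is needed, a higher number that more compound is needed for the effect), compound 1 gives > 25000 nM, which is a limit of the assay and not a number.
Compound 2 `N=C1CCN(S(=O)(=O)c2ccc(NC(=O)c3ccc([N+](=O)[O-])o3)cc2)CC1`: in this assay compound 2 gives > 25000 nM, again a limit.
Compound 3 `O=C(Nc1ccc(S(=O)(=O)N2CCOCC2)cc1)c1ccccc1`: in this assay compound 3 gives > 25000 nM, also a limit.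

All three measured compounds therefore sit at the same point, (the limit of > 25000 nM in this assay, at which 3 of the 3 values shown sit), and compound 3 is not placed any differently from the other two. Among the measured compounds shown here, the only step between measured compounds that differ in one place, a step that the two limits leave unreadable from compound 1 to compound 2, cannot be read, since both of its ends are limits.

The piece now turns to compound 4 `O=C(Nc1ccc(S(=O)(=O)N2CCOCC2)cc1)c1ccc([N+](=O)[O-])cc1`, which differs from compound 3 by nitro in place of hydrogen on an aromatic carbon. For the measured compounds named here, no measured step concerns a nitro group on this ring, and the one step available says nothing about size, so there is nothing to support an expectation of a change beyond the scatter in this assay. Compound 4 is expected to remain at the limit, with an estimated step that the limit leaves unreadable from compound 3 to compound 4. The estimate for compound 4 is 30000 nM, within 12000 nM to 100000 nM.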

Compound 4, half-maximal effective concentration: > 25000 nM
Compound 4: a limit, no number; the forecaster's own chance of this, stated with the estimate: 85%; the middle value does not contradict the limit.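

In this assay compound 4 gives > 25000 nM, a limit of the assay and not a number, so the step from compound 3 to compound 4 cannot be read. The compounds shown leave open whether nitro in place of hydrogen changes the value at all, since none of them has a readable number: the limit of > 25000 nM in this assay, at which 4 of the 4 values shown sit.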